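The compounds below may be only part of what the source reports. "The series", "measured", "known", "first", "only" and "open" are said of these compounds alone.

Measured so far in a functional assay on M21 cells (Homo sapiens) for antiproliferative activity, read by sulforhodamine B assay, with a stated time of 48 h; a higher number here means a weaker inhibitor, a lower number a stronger inhibitor:
Compound 1 `CC(C)c1ccccc1OS(=O)(=O)c1cccc(NC(=O)C(C)(C)C)c1`: 13000 nM
Compound 2 `CC(C)c1ccccc1OS(=O)(=O)c1cccc(NC(=O)CCl)c1`: 3900 nM
Compound 3 `CC(C)c1ccccc1OS(=O)(=O)c1ccc(NC(=O)C(C)(C)C)cc1`: 6200 nM

Compound 4 `CC(C)c1ccccc1OS(=O)(=O)c1ccc(NC(=O)CCl)cc1` has not yet been measured in this assay. Compound 3 and compound 1 have the same atoms joined differently; the difference between their two cores is not broken down here. Compound 4 arises from compound 3 by the change (chloromethyl in place of tert-butyl on a carbonyl carbon). The same change was made from compound 1 to compound 2, where it reads (chloromethyl in place of tert-butyl on a carbonyl carbon), and there it gave a 3.3-fold lower number from compound 1 to compound 2 (0.52 log units; beyond the scatter). Resting on that single earlier step, the step from compound 3 to compound 4 in this assay is expected to be of similar size, an estimated 3.1-fold lower number from compound 3 to compound 4 (0.49 log units; beyond the scatter). Compound 4 is therefore expected to give about 2000 nM, with a likely range from 900 nM to 4500 nM.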

Compound 4, half-maximal inhibitory concentration: 3900 nM
For compound 4 the middle estimate is 2.0-fold (0.29 log units) below the measured one, and the stated range covers the measured number.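

In this assay, chloromethyl in place of tert-butyl on the carbonyl carbon gave a 1.6-fold lower number from compound 3 to compound 4 (0.20 log units; within the scatter), a step that cannot be told apart from repeat measurement on this core. Set beside the earlier step, the change reads no differently on the two cores: the same change on two cores in this assay, a 3.3-fold lower number (0.52 log units; beyond the scatter) from compound 1 to compound 2 and a 1.6-fold lower number (0.20 log units; within the scatter) from compound 3 to compound 4, 2.1-fold (0.32 log units) apart, within the scatter of two such steps. Among these compounds, this shows that the two steps are compatible with one shared effect, but it does not show that the effect is constant or that it would hold on a further core, since it rests on only two pairs, and only the earlier step lies beyond the scatter.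

Going by these compounds, it stays open how a plain methyl or a bromomethyl on that carbonyl carbon would read in this assay. On these data alone, it also stays open whether an amine or a carboxylic acid there would follow the same course on both cores.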